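Pyrazolyl-to-imidazolyl swap on the piperazine arm

The compounds below may be only part of what the source reports. "The series", "measured", "known", "first", "only" and "open" are said of these compounds alone.

Measured compounds:
compound 1, `Cc1nc(C)c(CN2CCN(c3cccc4[nH]c(-c5ccc(C(C)(C)C)cc5)nc34)CC2)o1`, 31 nM
compound 2, `CCc1cc(CN2CCN(c3cccc4[nH]c(-c5ccc(C(C)(C)C)cc5)nc34)CC2)nn1C`, 43 nM

Both compounds were tested in an assay on isolated protein for displacement of a labelled ligand from Gonadotropin-releasing hormone receptor (Homo sapiens); on this read-out higher numbers stand for weaker inhibition and lower numbers for stronger inhibition. Compound 2 and compound 1 sit within the scatter of each other, as the step of a 1.4-fold higher number from compound 1 to compound 2 (0.14 log units; within the scatter) shows, so neither can be called the stronger or the weaker binder on these two numbers.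

Compound 3, `CCc1nc(CN2CCN(c3cccc4[nH]c(-c5ccc(C(C)(C)C)cc5)nc34)CC2)cn1C`, has not yet been measured. It differs from compound 2 by 2-ethyl-1-methyl-1H-imidazol-4-yl in place of 5-ethyl-1-methyl-1H-pyrazol-3-yl on a saturated chain carbon bound to an amine nitrogen in a ring. Within the data shown here, the only measured step that touches this position is the one from compound 1 to compound 2, where an oxazolyl group gave way to the pyrazolyl group and the number moved only within the scatter. Among the measured compounds shown here, the change to compound 3 is a rearrangement of the same atoms into an imidazolyl ring at the same place, and no measured step shows that such a swap matters here. The expected step is therefore a 1.1-fold lower number from compound 2 to compound 3 (0.03 log units; within the scatter), none beyond the scatter.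

Compound 3 is thus expected to give about 40 nM in this assay, with a range from 15 nM to 110 nM.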

Compound 3, half-maximal inhibitory concentration: 18 nM
The estimate for compound 3 lay 2.2-fold (0.35 log units) above the measured number; low and high end bracket the measured number.
By their numbers in this assay, from the lowest: compounds 3, 1 and 2 (each within the scatter of the next, the first and the last beyond it).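

In this assay, among these compounds, 2-ethyl-1-methyl-1H-imidazol-4-yl in place of 5-ethyl-1-methyl-1H-pyrazol-3-yl gives a 2.4-fold lower number from compound 2 to compound 3 (0.38 log units; beyond the scatter), a modest step beyond the scatter, and it is the first step at this place, on a saturated chain carbon bound to an amine nitrogen in a ring, to leave the scatter. The two groups have the same heavy atoms, hydrogen-bond donor and acceptor counts and net charge, so the number at this position can shift when only the way those atoms are joined differs. The 2,4-dimethyl-1,3-oxazol-5-yl group stays level with the imidazolyl group, with a 1.7-fold lower number from compound 1 to compound 3 (0.24 log units; within the scatter), and nothing shown accounts for the difference between the pyrazolyl and imidazolyl groups.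

The compounds shown leave open what the ethyl group on the imidazolyl ring contributes, which a methyl or isopropyl group in its place would address, and whether a 1,2,4-triazolyl or pyridinyl ring would fit this position as well. They also leave open whether the step from the pyrazolyl to the imidazolyl group would persist on a different core, since all three compounds share one.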